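A few compounds are considered here, and "the series" means these few. Any claim that something is new, unique, unknown or untested is made for them only; others in the source may bear on it.

The three measured compounds were tested in a functional assay on HCT-116 cells (Homo sapiens) for antiproliferative activity, read by MTT assay, with a stated time of 48 h; a lower number here means a stronger inhibitor, a higher number a weaker inhibitor. Compound 1, `CCCCCC(CCO)n1cnc2c(N)ncnc21`, reaches only a limit of the assay in this assay, reported as > 50000 nM. Compound 3, `CCCCCCC(CCO)n1cnc2c(N)ncnc21`, likewise reaches only a limit in this assay, reported as > 50000 nM. The two differ in one place: methyl in place of hydrogen on a saturated chain carbon, six bonds along the chain from an aromatic nitrogen. The step that the two limits leave unreadable from compound 1 to compound 3 cannot be sized because both values sit at the limit of > 50000 nM in this assay, at which 2 of the 3 values shown sit, so this change carries no readable size from these two compounds.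

Compound 2, `CCCCCCC(CCO)n1cnc2c(Cl)nc(F)nc21`, stands on a different core; how its core differs from that of compound 1 is not broken down here. In this assay, among the measured compounds shown here, compound 2 gives 9960 nM, the only actual number among the three measured values.

Compound 4, `CCCCCCCC(CCO)n1cnc2c(Cl)nc(F)nc21`, has not yet been measured in this assay. It differs from compound 2 by methyl in place of hydrogen on a saturated chain carbon, seven bonds along the chain from an aromatic nitrogen. The place is not the same as for the step from compound 1 to compound 3, where the methyl enters six bonds along the chain from an aromatic nitrogen rather than seven, so this is the same kind of change rather than the same change.

The step from compound 2 to compound 4 is expected to be a 1.0-fold higher number from compound 2 to compound 4 (0.00 log units; within the scatter), which rests on compound 2 giving 9960 nM and on the earlier step of this kind leaving no readable size. Compound 4 is therefore estimated at 10000 nM, expected to lie between 4000 nM and 25000 nM.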

Compound 4, half-maximal inhibitory concentration: 17600 nM
For compound 4 the middle estimate is 1.8-fold (0.25 log units) below the measured one; low and high end bracket the measured number.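

In this assay, adding the methyl on the core of compound 2 gives a 1.8-fold higher number from compound 2 to compound 4 (0.25 log units; within the scatter), so this step shows no readable effect of the change on that core. The same kind of change on the core of compound 1 offers no size to set beside it, because compound 1 and compound 3 both reach only a limit of the assay, not a number: the limit of > 50000 nM in this assay, at which 2 of the 4 values shown sit. With a single readable step, and with the methyl entering seven bonds along the chain from an aromatic nitrogen on one core but six bonds along on the other, these compounds show neither that the change carries from one core to the other nor that it fails to carry.

Compound 2 and compound 3 differ in more than one place on the core, so the compounds shown do not separate the contribution of each of those differences. As far as these compounds go, it also stays open how a still longer chain would behave on the core of compound 2, and whether a carboxylic acid at the end of the chain would leave the result in this range.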